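The compounds below may be only part of what the source reports. "The series", "measured", "known", "first", "only" and "open" are said of these compounds alone.

Measured compounds:

- Compound 1, `O=C1CCCC2=C1C(c1ccc(F)cc1)C=C(c1ccccc1)N2`: 21.9%
- Compound 2, `O=C1CCCC2=C1C(c1ccc(Cl)cc1)C=C(c1ccccc1)N2`: 8.21%
- Compound 3, `CCOC(=O)C1=CC(c2ccc(F)cc2)C2=C(CC(C)(C)CC2=O)N1`: "not active" (no number reported)

The three compounds were tested in an assay on isolated protein for inhibition of glucose-6-phosphatase catalytic subunit 1 (Homo sapiens), read by inositol phosphate accumulation, with a stated time of 30 min, tested at 100 uM; on this read-out higher numbers stand for more inhibition at the one concentration tested (going by the name of the read-out) and lower numbers for less inhibition. Compound 1 gives 21.9%, while compound 2, which carries chloro in place of fluoro on an aromatic carbon, gives 8.21%. The step between the two is a number 13.7 percentage points lower from compound 1 to compound 2 (beyond the scatter); the change itself is chloro in place of fluoro on an aromatic carbon. Compound 3, built on a different core, is reported in this assay as "not active" (no number reported), with no number attached. How the core of compound 3 differs from that of compound 1 is not broken down here.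

Compound 4, `CCOC(=O)C1=CC(c2ccc(Cl)cc2)C2=C(CC(C)(C)CC2=O)N1`, has not been measured. It stands to compound 3 exactly as compound 2 stands to compound 1: the change is chloro in place of fluoro on an aromatic carbon, at the same place, para to a large group, and so it is the same change seen once already. Among the measured compounds shown here, the only guide to its size is the earlier pair, where chloro in place of fluoro lowered the read-out in this assay for compound 2 relative to compound 1. Given that compound 3 is already reported as not active, compound 4 is expected to remain at or near the bottom of the scale in this assay, and may again be reported only as not active rather than with a number. Compound 4 is estimated at 5%, with a range from -10% to 20%.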

Compound 4, a percentage reported as inhibition, at one concentration (the size of the read-out at that concentration, not a potency): 11.3%
Compound 4: the middle estimate sits 6.3 percentage points below what was measured, and the stated range covers the measured number.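

In this assay, among the compounds shown here, compound 3 is reported as "not active" (no number reported) while compound 4 gives 11.3% and so no step between the two can be read. The compounds shown leave open whether chloro in place of fluoro shifts the read-out on the core of compound 3 as it does on the core of compound 1. No supporting data bear on this result.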